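The source may hold more compounds than are shown below. What is called first, only, known or untested is meant among the compounds shown, and "the series" means these compounds.

Compound 2 `CC#CC(c1ccc(Oc2ccc(C(F)(F)F)cc2OC(F)F)cc1)C1OC(=O)NC1=O` gives 266 nM in a functional assay on CHO cells for agonist activity at Free fatty acid receptor 1 (Mus musculus), read by FLIPR and calcium flux; a higher number here means that more compound is needed for the effect, a lower number that less compound is needed; of the two values seen so far this is the higher one, but the nearest neighbour lies within the scatter. That neighbour, compound 1 `CC#C[C@@H](c1ccc(Oc2ccc(C(F)(F)F)cc2OC(F)F)cc1)[C@H]1OC(=O)NC1=O`, gives 136 nM in this assay, and the step of a 2.0-fold higher number from compound 1 to compound 2 (0.29 log units; within the scatter) concerns only the drawn configurations, as the fact that one of compounds 1 and 2 is drawn with a defined configuration and the other without, at the place where they differ shows. Compound 3 `CC#C[C@H](c1ccc(Oc2ccc(C(F)(F)F)cc2OC(F)F)cc1)[C@H]1OC(=O)NC1=O` differs from compound 2 by the two compounds have the same atoms and bonds; at least one stereo element is drawn with a configuration in one of them and without one in the other: 2 of 2 stereo elements differ; a stereocentre at a saturated chain carbon is drawn without a configuration in compound 2 and S in compound 3; a stereocentre at a saturated ring carbon is drawn without a configuration in compound 2 and R in compound 3. Within the data shown here, the one measured step that bears on such a change is small, so no large shift beyond the scatter is expected; the estimate for compound 3 is 500 nM (range 150 nM to 2000 nM), a step of a 1.9-fold higher number from compound 2 to compound 3 (0.27 log units; within the scatter).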

Compound 3, half-maximal effective concentration: 7060 nM
For compound 3 the middle estimate is 14-fold (1.15 log units) below the measured one; the whole stated range lies below it.
By their numbers in this assay, from the lowest: compounds 1 and 2 (each within the scatter of the next); then compound 3.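

In this assay, the configuration at the saturated chain carbon now emerges as decisive: moving it from R to S, with the saturated ring carbon drawn R throughout, gives a 52-fold higher number from compound 1 to compound 3 (1.72 log units; beyond the scatter). That large step is a matter of configuration alone: the fact that compounds 1 and 3 differ only in the configuration as drawn The step of a 27-fold higher number from compound 2 to compound 3 (1.42 log units; beyond the scatter) is also large, a separation the earlier pair, lying within the scatter, could not reveal: the fact that one of compounds 2 and 3 is drawn with a defined configuration and the other without, at the place where they differ

Going by these compounds, the role of the saturated ring carbon remains open, as it is drawn R in both compound 1 and compound 3. Also open, on these data alone, is whether a longer chain at the saturated chain carbon would keep this dependence on configuration.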